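The source may report more compounds than this note shows. Statements on the series, on what has been measured and on what is new or still open speak of the compounds shown alone.

Of the compounds shown here, three sharing one core have been tested in a functional assay on the whole organism for inhibition, with Nicotiana tabacum as the target; a lower number here means a stronger inhibitor, a higher number a weaker inhibitor. Compound 1 `Cc1nc(Nc2ccc(Cl)cc2)c2cc[nH]c2n1` gives 224000000 nM, compound 2 `CCc1ccc(Nc2[nH]c(C)nc3nccc2-3)cc1` gives 214000000 nM, and compound 3 `Cc1nc(Nc2ccc(O)cc2)c2cc[nH]c2n1` gives 155000000 nM. Compound 2 stands among the others with no gap beyond the scatter: its number differs from compound 1 and from compound 3 by less than repeated measurement would resolve. Among the compounds with values here, the one single-point step seen so far, a 1.4-fold lower number from compound 1 to compound 3 (0.16 log units; within the scatter), also stayed within the scatter. Compound 4 `CC(=O)c1ccc(Nc2[nH]c(C)nc3nccc2-3)cc1` differs from compound 2 by acetyl in place of ethyl on an aromatic carbon. Within the data shown here, no measured step exchanges ethyl for acetyl; the only guide is how little the one measured step moved. Compound 4 is therefore expected to give 200000000 nM, with a range from 60000000 nM to 600000000 nM. The step of a 1.1-fold lower number from compound 2 to compound 4 (0.03 log units; within the scatter) is expected to stay within the scatter.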

Compound 4, half-maximal inhibitory concentration: 646000000 nM
The estimate for compound 4 lay 3.2-fold (0.51 log units) below the measured number; the measured number lies above the stated range.
By their numbers in this assay, from the lowest: compounds 3, 2 and 1 (each within the scatter of the next); then compound 4.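

In this assay, within the data shown here, this position on the aromatic ring, para to a large group, responds to the change: acetyl in place of ethyl gives a 3.0-fold higher number from compound 2 to compound 4 (0.48 log units; beyond the scatter), a modest loss of inhibition and the first single change here to lie beyond the scatter. The earlier step, a 1.4-fold lower number from compound 1 to compound 3 (0.16 log units; within the scatter), did not show such a difference. No measurement available here explains the loss, and it cannot be assigned to the added oxygen or the new double bond. Going by these compounds, it remains open how a methoxy group, an amine or a carboxylic acid at this position would compare with ethyl and acetyl. A longer chain, such as propyl, would show whether the size of the group alone changes the number.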